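This account rests on a few compounds, and the source may have more. Where it says the series, first, only, none or still open, it means among the compounds named here.

Compound 1, `CCCOCNc1n[n+]([O-])c2cc(OC)ccc2[n+]1[O-]`, 6570 nM
Compound 2, `COc1ccc(COCNc2n[n+]([O-])c3ccccc3[n+]2[O-])cc1`, 14500 nM

In a functional assay on PC-3 cells (Homo sapiens) for cytotoxicity, read by MTT assay, with a stated time of 72 h (a higher number here means a weaker inhibitor, a lower number a stronger inhibitor), compound 1 gives the lower of the two numbers shown, and compound 2 gives a number that is higher by a margin beyond the usual scatter. For the measured compounds named here, compound 2 differs from compound 1 in more than one place, so their two values show only that compound 2 is the weaker of the pair, not which part of the structure accounts for it.

Compound 3, `COc1ccc2c(c1)[n+]([O-])nc(NCOC(C)c1ccccc1)[n+]2[O-]`, has not been measured. It differs from compound 1 in a single place: 1-phenylethyl in place of propyl on an oxygen on a saturated carbon. Going by the values given here, no measured pair tracks this kind of change, so there is no step to lean on. On the data available, a step of no more than the usual scatter is expected from compound 1 to compound 3, with no clear direction: a 1.1-fold lower number from compound 1 to compound 3 (0.04 log units; within the scatter). Compound 3 is therefore estimated at 6000 nM, within a range from 2500 nM to 15000 nM.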

Compound 3, half-maximal inhibitory concentration: 4140 nM
Estimate against measurement, compound 3: 1.4-fold (0.16 log units) above; low and high end bracket the measured number.
By their numbers in this assay, from the lowest: compounds 3 and 1 (each within the scatter of the next); then compound 2.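

In this assay, putting 1-phenylethyl in place of propyl on an oxygen on a saturated carbon gives a 1.6-fold lower number from compound 1 to compound 3 (0.20 log units; within the scatter) and so leaves the two values within the scatter of each other. For the compounds shown here, compounds 1 and 2 differ in more than one place, so this single-place pair is the first direct view of this position: here, a much larger group carrying an aromatic ring gives a value that cannot be told apart from that of the small propyl chain. Nothing measured here explains this result.

The compounds shown leave open whether a longer chain, an amine or a carboxylic acid at this position would also stay within the scatter of compound 1. They also leave open how far this one pair holds on a different core, such as that of compound 2.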